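A few compounds are considered here, and "the series" means these few. Any claim that something is new, unique, unknown or untested is made for them only; others in the source may bear on it.

In an ADME assay on Huh-7 cells (Homo sapiens) for cytotoxicity, with a stated time of 3 days (on this read-out higher numbers stand for lower toxicity in this test and lower numbers for higher toxicity in this test), compound 1, `O=C(Nc1ccccc1O)c1c(NO)cc(-c2ccccc2)oc1=O`, gives 14000 nM. Compound 2, `Cc1ccc(-c2cc(NO)c(C(=O)NC3CCCCC3)c(=O)o2)cc1`, gives 10100 nM in this assay. For compound 3, `O=C(Nc1ccccc1)c1c(NO)cc(-c2cccs2)oc1=O`, this assay yields only a limit, > 20000 nM, and not a number. Compound 3 therefore stands at the limit of > 20000 nM in this assay, at which 1 of the 3 values shown sits, the least toxic position among the three values shown, though how far beyond that line it lies is not known. Going by the values given here, no two of the three measured compounds differ from each other in a single place, so no measured step is available to guide the next one.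

Compound 4, `Cc1ccc(NC(=O)c2c(NO)cc(-c3cccs3)oc2=O)cc1`, is the unmeasured compound of the set. It differs from compound 3 by methyl in place of hydrogen on an aromatic carbon. Without a measured step for this change, one would expect a step in this assay of no size beyond the usual scatter, in no firm direction. For compound 4 the expected value in this assay is 18000 nM, with a range from 7000 nM to 40000 nM, which is an estimated step of an at least 1.1-fold lower number from compound 3 to compound 4 (0.04 log units; that floor lies within the scatter). The estimate carries a fair chance that the assay again reports only a limit.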

Compound 4, half-maximal cytotoxic concentration: > 20000 nM
Compound 4: a limit, no number; the forecaster's own chance of this, stated with the estimate: 50%; at least 1.1-fold (0.04 log units) between middle value and limit.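

Compound 3 and compound 4 both return only a limit in this assay, so the step for methyl in place of hydrogen on an aromatic carbon cannot be read: the limit of > 20000 nM in this assay, at which 2 of the 4 values shown sit. The compounds shown leave open how far beyond that limit either compound lies, and whether the two differ at all.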